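Triazolopyridine piperidines: fluorination of the methoxyphenyl ring

The source may report more compounds than this note shows. Statements on the series, on what has been measured and on what is new or still open speak of the compounds shown alone.

Two compounds of the series have been run in a functional assay on CHO cells for agonist activity at metabotropic glutamate receptor 2 (Homo sapiens), read by scintillation counting and GTPgammaS binding, with a stated time of 30 min; a higher number here means that more compound is needed for the effect, a lower number that less compound is needed. Compound 1 `COc1c(F)cccc1C1CCN(c2ccn3c(CC(F)(F)F)nnc3c2C#N)CC1` gives 31 nM in this assay. Compound 2 `COc1ccccc1C1CCN(c2ccn3c(CC4CC4)nnc3c2Cl)CC1` gives 20 nM in this assay, the lowest of the two numbers, though its gap to compound 1 lies within the usual scatter, so no order between them can be read. For the measured compounds named here, compound 1 and compound 2 also differ in several places at once, so the pair gives no single-point step to lean on.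

Compound 3 `COc1c(C2CCN(c3ccn4c(CC5CC5)nnc4c3Cl)CC2)ccc(F)c1F` has not yet been measured. It keeps the core of compound 2 and changes only the aryl group on the piperidine: 3,4-difluoro-2-methoxyphenyl in place of 2-methoxyphenyl on a saturated ring carbon. Going by the values given here, no measured pair isolates this change, so the expected direction rests on compound 2 alone, as 20 nM, and on the general observation that the fluorinated aryl of compound 1 sits close to compound 2. The step from compound 2 to compound 3 in this assay is expected to stay within the scatter, a 1.3-fold lower number from compound 2 to compound 3 (0.10 log units; within the scatter), with no clear gain or loss. Compound 3 is estimated at 16 nM, in a range from 5 nM to 50 nM.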

Compound 3, half-maximal effective concentration: 26 nM
Compound 3: the middle estimate sits 1.6-fold (0.21 log units) below what was measured; the range from low to high includes it.
By their numbers in this assay, from the lowest: compounds 2, 3 and 1 (each within the scatter of the next).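

Working notes. Placing 3,4-difluoro-2-methoxyphenyl in place of 2-methoxyphenyl on a saturated ring carbon gives, in this assay, a 1.3-fold higher number from compound 2 to compound 3 (0.11 log units; within the scatter), and this is the first step in the series that isolates a single place. On these data alone, the aryl group on this ring carbon therefore takes the two added fluorine atoms, going from 8 to 10 heavy atoms, with no gain or loss that can be read from the numbers, while the methoxy group stays in both compounds and its own contribution remains untested here. Nothing available accounts for this flat step, and no supporting data bear on it.

Still open, as far as these compounds go, is whether the aryl group accepts replacements other than fluorine at these positions, such as a chlorine atom, a hydroxyl group or an aminomethyl group, and whether either fluorine alone would give the same reading in this assay. Also open, from the compounds shown here alone, is whether the same exchange behaves alike on the core of compound 1, which differs from compound 3 in several places at once and so offers no single-place comparison with it.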